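Amide Aryl Variation in a Growth Inhibition Series

A few compounds are considered here, and "the series" means these few. Any claim that something is new, unique, unknown or untested is made for them only; others in the source may bear on it.

Measured so far in a functional assay on T47D cells (Homo sapiens) for inhibition, read by CCK-8 assay, with a stated time of 72 h, tested at 10 uM; a lower number here means less inhibition of growth, a higher number more inhibition of growth at the concentration tested:
compound 1 `CN(C)C(=O)c1cc2cnc(Nc3ccc(NC(=O)C4(C(=O)Nc5cccc(F)c5)CC4)cc3)nc2n1C1CCCC1` gives -0.4%
compound 2 `CN(C)C(=O)c1cc2cnc(Nc3ccc(NC(=O)C4(C(=O)Nc5ccc(Cl)c(C(F)(F)F)c5)CC4)cc3)nc2n1C1CCCC1` gives 55.8%
compound 3 `CN(C)C(=O)c1cc2cnc(Nc3ccc(NC(=O)C4(C(=O)Nc5cccc(C(F)(F)F)c5)CC4)cc3)nc2n1C1CCCC1` gives 92.7%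

Compound 1 stands lowest of the three numbers. Its nearest neighbour is compound 2, reached by a number 56.2 percentage points higher from compound 1 to compound 2 (beyond the scatter); its furthest is compound 3, reached by a number 93.1 percentage points higher from compound 1 to compound 3 (beyond the scatter). Between the two higher compounds the step is a number 36.9 percentage points higher from compound 2 to compound 3 (beyond the scatter).

Compound 4 `CN(C)C(=O)c1cc2cnc(Nc3ccc(NC(=O)C4(C(=O)Nc5ccc(C(F)(F)F)cc5)CC4)cc3)nc2n1C1CCCC1` differs from compound 1 by 4-(trifluoromethyl)phenyl in place of 3-fluorophenyl on an amide-type nitrogen. Among the compounds with values here, two measured steps bear on this change. The step from compound 1 to compound 3 also exchanges fluoro for trifluoromethyl on the aryl amide and is large upward. The step from compound 1 to compound 2 replaces the whole 3-fluorophenyl with another trifluoromethyl-bearing aryl and is likewise large upward. Within the data shown here, no measured pair separates the ring position of the trifluoromethyl, so the size is uncertain, but both steps point the same way. A large upward step in this assay is therefore expected, estimated as a number 70.4 percentage points higher from compound 1 to compound 4 (beyond the scatter). Compound 4 is expected to give about 70%, within 30% to 95%.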

Compound 4, percent growth inhibition at one concentration: 94.9%
Compound 4: middle estimate off by 24.9 percentage points, on the low side; low and high end bracket the measured number.
By their numbers in this assay, from the lowest: compound 1; then compound 2; then compounds 3 and 4 (each within the scatter of the next).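

In this assay the change from 3-(trifluoromethyl)phenyl to 4-(trifluoromethyl)phenyl on the amide-type nitrogen gives a number 2.2 percentage points higher from compound 3 to compound 4 (within the scatter) and so the two trifluoromethyl placements shown cannot be told apart, while the change from 3-fluorophenyl gives a number 95.3 percentage points higher from compound 1 to compound 4 (beyond the scatter) as a second large step to a trifluoromethyl-bearing aryl. The change from 4-chloro-3-(trifluoromethyl)phenyl gives a number 39.1 percentage points higher from compound 2 to compound 4 (beyond the scatter) and so, of the three trifluoromethyl-bearing aryl groups shown, only the one that also carries chloro stands apart. No measured evidence accounts for these differences.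

The compounds shown leave open how an aryl ring carrying an amine, a carboxylic acid or a methoxy group in place of trifluoromethyl would read in this assay. They also leave open whether 4-fluorophenyl would read like compound 1 or like compound 4.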